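Permeability notes: from compound 3 to compound 4

This account rests on a few compounds, and the source may have more. Where it says the series, first, only, none or still open, it means among the compounds named here.

Measured so far:
compound 1, `FC(F)(F)c1ccc(-c2ccc3c(NCCCNCc4ccco4)ccnc3c2)cc1`: 237 10^-6 cm/s
compound 2, `Fc1ccc(Cc2ccc3c(NCCCNCc4ccco4)ccnc3c2)cc1`: 23 10^-6 cm/s
compound 3, `c1ccc(Cc2ccc3c(NCCCNCc4ccco4)ccnc3c2)cc1`: 23 10^-6 cm/s

In an ADME assay for permeability, using PAMPA, with a stated time of 30 min, at pH 7.4 (a higher number here means that the compound crosses the layer faster, a lower number that the compound crosses the layer more slowly), compound 3 gives 23 10^-6 cm/s, level with compound 2 at the digits shown; together these two are the lowest of the three numbers. Compound 1 is the furthest away, the gap being a 10-fold lower number from compound 1 to compound 3 (1.01 log units; beyond the scatter).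

Compound 4, `COc1ccc(-c2ccc3c(NCCCNCc4ccco4)ccnc3c2)cc1`, differs from compound 3 by 4-methoxyphenyl in place of benzyl on an aromatic carbon. Within the data shown here, two measured steps bear on this. Both a 10-fold lower number from compound 1 to compound 3 (1.01 log units; beyond the scatter) and a 10-fold lower number from compound 1 to compound 2 (1.01 log units; beyond the scatter) show the same large drop when a group bound directly to the shared core is exchanged for benzyl or 4-fluorobenzyl, while no change at the digits printed from compound 2 to compound 3 (within the scatter) shows that fluoro on the benzyl changes nothing beyond the scatter. Among the measured compounds shown here, no measured pair separates 4-methoxyphenyl from 4-(trifluoromethyl)phenyl, so where compound 4 sits relative to compound 1 is open. In this assay the step is expected to be a 4.3-fold higher number from compound 3 to compound 4 (0.64 log units; beyond the scatter), because compound 1 gives 237 10^-6 cm/s. Compound 4 is therefore estimated at 100 10^-6 cm/s, with a range of 40 10^-6 cm/s to 250 10^-6 cm/s.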

Compound 4, apparent permeability: 237 10^-6 cm/s
The estimate for compound 4 lay 2.4-fold (0.37 log units) below the measured number; the range from low to high includes it.
By their numbers in this assay, from the lowest: compounds 2 and 3 (each within the scatter of the next); then compounds 1 and 4 (each within the scatter of the next).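

In this assay, a ring bound directly to the shared core is now seen with a second substituent: 4-methoxyphenyl in place of benzyl gives a 10-fold higher number from compound 3 to compound 4 (1.01 log units; beyond the scatter), and 4-methoxyphenyl in place of 4-fluorobenzyl gives a 10-fold higher number from compound 2 to compound 4 (1.01 log units; beyond the scatter), so the large gap is not tied to trifluoromethyl. Methoxy in place of trifluoromethyl gives no change at the digits printed from compound 1 to compound 4 (within the scatter), which places the two substituted phenyl compounds level with each other and the two benzyl compounds level with each other, and no compound shown goes against this split. Nothing available explains the split.

On these data alone, whether it holds for a phenyl carrying an amine or a carboxylic acid, or for a longer chain linking the ring to the core, stays open. The side chain is the same in all four compounds, so its part in these numbers cannot be read.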